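A few compounds are considered here, and "the series" means these few. Any claim that something is new, unique, unknown or untested is made for them only; others in the source may bear on it.

Measured compounds in an assay on CHO-K1 cells for displacement of a labelled ligand from prostaglandin E2 receptor EP1 subtype (Homo sapiens); a lower number here means a stronger inhibitor, a higher number a weaker inhibitor:
compound 1, `Cc1cc(NC(=O)C(C)C)nn1Cc1cc(Cl)ccc1OCc1ccccc1`, 25.1 nM
compound 2, `Cc1cc(NC(=O)C2CCCC2)nn1Cc1cc(Cl)ccc1OCc1ccccc1`, 15.9 nM
compound 3, `Cc1cc(NC(=O)C2CCOCC2)nn1Cc1cc(Cl)ccc1OCc1ccccc1`, 63.1 nM

Compound 3 gives the highest number of the three; the steps of a 2.5-fold higher number from compound 1 to compound 3 (0.40 log units; beyond the scatter) and a 4.0-fold higher number from compound 2 to compound 3 (0.60 log units; beyond the scatter) both run toward it, while a 1.6-fold lower number from compound 1 to compound 2 (0.20 log units; within the scatter) stays within the scatter. Compound 4, `Cc1cc(NC(=O)O[C@H]2CCOC2)nn1Cc1cc(Cl)ccc1OCc1ccccc1`, differs from compound 3 by (oxolan-3-yl)oxy in place of oxan-4-yl on a carbonyl carbon. Within the data shown here, all measured steps alter the group on the carbonyl carbon, and the two reaching compound 3 were modest; none swaps that group for an oxygen-linked one, so no direct precedent exists. For compound 4 a step of at most modest size is expected, without a clear direction, and a 1.0-fold lower number from compound 3 to compound 4 (0.00 log units; within the scatter) is the estimated step. For compound 4 the expected value in this assay is 63 nM, within 20 nM to 200 nM.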

Compound 4, half-maximal inhibitory concentration: 79.4 nM
For compound 4 the middle estimate is 1.3-fold (0.10 log units) below the measured one, within the range that was stated.
By their numbers in this assay, from the lowest: compounds 2 and 1 (each within the scatter of the next); then compounds 3 and 4 (each within the scatter of the next).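

With (oxolan-3-yl)oxy in place of oxan-4-yl on the carbonyl carbon, this assay shows that an oxygen-linked group reads level with the carbon-linked one: a 1.3-fold higher number from compound 3 to compound 4 (0.10 log units; within the scatter) stays inside the scatter. The gap to the two groups without a ring oxygen remains, with a 5.0-fold higher number from compound 2 to compound 4 (0.70 log units; beyond the scatter) and a 3.2-fold higher number from compound 1 to compound 4 (0.50 log units; beyond the scatter) both beyond the scatter and modest in size. No supporting data bear on these steps.

Open, on these data alone, is whether isopropoxy or cyclopentyloxy on the carbonyl carbon would read level with compound 1 and compound 2, which would separate the oxygen link from the ring oxygen. Also open, as far as these compounds go, is how an amine such as piperidin-4-yl would read at this place.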